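The source may report more compounds than this note shows. Statements on the series, on what has been measured and on what is new or still open speak of the compounds shown alone.

Measured so far in a functional assay on MDA-MB-231 cells (Homo sapiens) for inhibition, read by CCK-8 assay, with a stated time of 48 h; on this read-out higher numbers stand for weaker inhibition of growth and lower numbers for stronger inhibition of growth:

Compound 1 `Cc1ccc(Nc2ncc(Cl)c(Nc3ccccc3C)n2)cc1`: > 100000 nM, a limit of the assay and not a number.
Compound 2 `Cc1ccccc1Nc1nc(Nc2ccc(N3CCN(C)CC3)cn2)ncc1Cl`: 7470 nM.

For the measured compounds named here, compound 2 holds the only true number so far, since the other result is a limit. Compound 3 `Cc1ccccc1Nc1nc(Nc2ccc(N3CCCCC3)cn2)ncc1Cl` differs from compound 2 in one place, with piperidin-1-yl in place of 4-methylpiperazin-1-yl on an aromatic carbon of a six-membered aromatic ring with 1 nitrogen: piperidin-1-yl in place of 4-methylpiperazin-1-yl on an aromatic carbon. Going by the values given here, no step of this kind has been measured, so the expectation is loose. Among the compounds with values here, the sole numerical anchor is compound 2 at 7470 nM. A modest weakening of growth inhibition in this assay is expected, not far beyond the usual scatter. The expected step is a 1.3-fold higher number from compound 2 to compound 3 (0.13 log units; within the scatter). For compound 3 the estimated value is 10000 nM, with an expected range of 3000 nM to 40000 nM.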

Compound 3, concentration for 50% growth inhibition: > 100000 nM
Compound 3 ended at the assay's limit; the forecaster's own chance of this, stated with the estimate: 15%; middle value at least 10-fold (1.00 log units) away from the limit.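

Within the series, only compound 2 gives a true number in this assay, and the first measured change at this position, two atoms from the ring nitrogen and para to a large group, is large: piperidin-1-yl in place of 4-methylpiperazin-1-yl gives an at least 13-fold higher number from compound 2 to compound 3 (1.12 log units; beyond the scatter). Growth inhibition in this assay therefore depends strongly on this group, and the loss of one ring hetero atom with its methyl-bearing nitrogen is not a neutral swap here. The step can be read only as a lower bound because the result for compound 3 is a limit and not a number: the limit of > 100000 nM in this assay, at which 2 of the 3 values shown sit.

From the compounds shown here alone, it remains open whether the ring nitrogen itself or its methyl group matters. Piperazin-1-yl without the methyl, or morpholin-4-yl with a ring oxygen at that place, would separate these two readings.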